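A few compounds are considered here, and "the series" means these few. Any claim that something is new, unique, unknown or untested is made for them only; others in the source may bear on it.

Measured so far:
compound 1, `CCC(CC)(c1nnc[nH]1)c1ccc(-c2ccc3cccc(F)c3c2)[nH]c1=O` — 31200 nM
compound 2, `CC(C)C(c1nnc[nH]1)c1ccc(-c2ccc3cccc(F)c3c2)[nH]c1=O` — 24500 nM

In a physicochemical assay for solubility, in phosphate buffer, measured as kinetic solubility (a lower number here means a less soluble compound, a higher number a more soluble compound), compound 2 stands at the lower of the two numbers, but the nearest value, that of compound 1, lies within the scatter, so no order between compound 1 and compound 2 is claimed.

Compound 3, `CC(C)NC(=O)CC(c1ccc(-c2ccc3cccc(F)c3c2)[nH]c1=O)C(C)C`, has not yet been measured in this assay. Compared with compound 2 the change is (isopropylcarbamoyl)methyl in place of 4H-1,2,4-triazol-3-yl on a saturated chain carbon bound to an aromatic carbon and a saturated chain carbon. Going by the values given here, no pair of measured compounds differs in this way, so the size of the step has no measured precedent. The step of a 2.0-fold lower number from compound 2 to compound 3 (0.31 log units; beyond the scatter) is expected to run downward and to lie beyond the scatter. Compound 3 is accordingly estimated at 12000 nM in this assay, with a range from 4000 nM to 36000 nM.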

Compound 3, solubility: 18000 nM
For compound 3 the middle estimate is 1.5-fold (0.18 log units) below the measured one; the measured number falls inside the stated range.
By their numbers in this assay, from the lowest: compounds 3, 2 and 1 (each within the scatter of the next).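

In this assay, going by these compounds alone, the first change at this position, on a saturated chain carbon bound to an aromatic carbon and a saturated chain carbon, gives a 1.4-fold lower number from compound 2 to compound 3 (0.13 log units; within the scatter). Within the data shown here, an open (isopropylcarbamoyl)methyl group with no ring therefore stands in place of the five-membered aromatic ring of 4H-1,2,4-triazol-3-yl without a resolved difference, which the earlier compounds could not show because neither lacks that ring. No measurement at hand explains this outcome.

Open, on these data alone, is whether a carboxylic acid or an amine at this position would give a step beyond the scatter in this assay. Also open, as far as these compounds go, is whether a longer chain between this carbon and the carbonyl would leave the number as unresolved as the (isopropylcarbamoyl)methyl group does.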